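Methoxy Substitution and Cytotoxicity in Pancreatic Cancer Cells

The compounds below may be only part of what the source reports. "The series", "measured", "known", "first", "only" and "open" are said of these compounds alone.

Compound 1 `C=C1C(=O)O[C@@H](c2ccccc2)[C@H]1C` and compound 2 `C=C1C(=O)O[C@@H](c2ccc(OC)cc2)[C@H]1C` were compared in a functional assay on PANC-1 cells (Homo sapiens) for cytotoxicity, read by MTT assay, with a stated time of 72 h, tested at 10 uM; on this read-out higher numbers stand for a weaker effect at the one concentration tested and lower numbers for a stronger effect. In that assay compound 1 gives 62%, while compound 2 gives 32%. The structural change between them is methoxy in place of hydrogen on an aromatic carbon, and the resulting step is a number 30 percentage points lower from compound 1 to compound 2 (beyond the scatter). Compound 3 `C=C1C(=O)O[C@H](c2ccccc2)[C@H]1c1ccccc1` belongs to a related series, but the difference between the two cores is not broken down here. In this assay compound 3 gives 1%, the lowest of the three numbers, beyond the scatter from both others.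

Compound 4 `C=C1C(=O)O[C@H](c2ccc(OC)cc2)[C@H]1c1ccccc1` has not yet been measured. It differs from compound 3 by methoxy in place of hydrogen on an aromatic carbon, the same kind of change as that from compound 1 to compound 2, though the surroundings differ: here the methoxy sits para to a large group, whereas in compound 2 it is para to a group of 8 heavy atoms. The expected step here, a number 1 percentage points higher from compound 3 to compound 4 (within the scatter), is far smaller than the earlier one because compound 3 already gives 1%, leaving little room for a further fall. Compound 4 is therefore estimated at 2%, most likely between 0% and 12%.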

Compound 4, a percentage reported as activity, at one concentration (the size of the read-out at that concentration, not a potency): 0%
For compound 4 the middle estimate is 2 percentage points above the measured one, and the stated range covers the measured number.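

Methoxy in place of hydrogen on an aromatic carbon of the core of compound 3 gives a number 1 percentage points lower from compound 3 to compound 4 (within the scatter) in this assay. Set beside the earlier step, the size of this change does not carry from one core to the other: the same change on two cores in this assay, a number 30 percentage points lower (beyond the scatter) from compound 1 to compound 2 and a number 1 percentage points lower (within the scatter) from compound 3 to compound 4, 29 percentage points apart, beyond the scatter of two such steps
Compound 3 gives 1% and compound 4 gives 0%, both close to the low end of the read-out, and this pair does not show that methoxy has no effect on this core, nor do two pairs establish a rule for the series.

The compounds shown leave open how other groups in the same place, such as chlorine, an amine or a carboxylic acid, would behave on either core. Also open, as far as these compounds go, is whether a test at a lower concentration would separate compound 3 from compound 4.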